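Solubility at Neutral pH across a Shared Quinazoline-Type Core Series

A few compounds are considered here, and "the series" means these few. Any claim that something is new, unique, unknown or untested is made for them only; others in the source may bear on it.

Compound 1 `CNC(=O)c1cc(Oc2ccc3nc(Nc4cccc(C(C)(C)C)c4)ncc3c2)ccn1` — in a physicochemical assay for solubility, at pH 7 (a higher number here means a more soluble compound, a lower number a less soluble compound), compound 1 gives < 1000 nM, a limit of the assay.
Compound 2 `CNC(=O)c1cc(Oc2ccc3nc(Nc4cccc(C(C)(C)C)c4)cnc3c2)ccn1` — in this assay compound 2 gives < 1000 nM, a limit of the assay.
Compound 3 `CNC(=O)c1cc(Oc2ccc3nc(Nc4ccccc4Br)ncc3c2)ccn1` — in this assay compound 3 gives < 1000 nM, a limit of the assay.

Compound 3 therefore stands at a limit rather than at a number, and the two further values shown sit at the same limit (the limit of < 1000 nM in this assay, at which 3 of the 3 values shown sit). Going by the values given here, the one measured step that touches compound 3, a step that the two limits leave unreadable from compound 1 to compound 3, runs between two limits and its size cannot be read.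

Compound 4 `CNC(=O)c1cc(Oc2ccc3nc(Nc4ccccc4Oc4ccccc4)ncc3c2)ccn1` differs from compound 3 by phenoxy in place of bromo on an aromatic carbon. Among the compounds with values here, no measured step tells how a phenoxy group in this place moves solubility, so the expectation rests on where all three measured compounds stand. Because every value shown sits at the limit (the limit of < 1000 nM in this assay, at which 3 of the 3 values shown sit), the step that the limit leaves unreadable from compound 3 to compound 4 is estimated to leave compound 4 in the same region, most likely again returned only as a limit. Compound 4 is thus expected to give about 400 nM in this assay, with a range from 80 nM to 2000 nM.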

Compound 4, solubility: < 1000 nM
Compound 4: no number, only a limit; the forecaster's own chance of this, stated with the estimate: 70%; the middle value is on the limit's open side.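

Compound 3 and compound 4 both stand at a limit in this assay, so no size can be read for the step between them, and the series now rests entirely on one limit: the limit of < 1000 nM in this assay, at which 4 of the 4 values shown sit.

The compounds shown leave open where the true solubility of each lies, and whether any change to the shared core would give a readable number.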